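Aryl swap on the ring amine: expectation for compound 4

A few compounds are considered here, and "the series" means these few. Any claim that something is new, unique, unknown or untested is made for them only; others in the source may bear on it.

Measured compounds:
compound 1 `COc1ccc(N2CCN(Cn3nc(-c4ccc5c(c4)OCCO5)oc3=S)CC2)cc1` – > 50000 nM
compound 2 `Cc1ccc(N2CCN(Cn3nc(-c4ccc5c(c4)OCCO5)oc3=S)CC2)c(C)c1` – 28400 nM
compound 3 `S=c1oc(-c2ccc3c(c2)OCCO3)nn1CN1CCN(c2cccc(Cl)c2Cl)CC1` – > 50000 nM

For the measured compounds named here, in a functional assay on HepG2 cells (Homo sapiens) for antiproliferative activity, read by MTT assay, with a stated time of 48 h (a lower number here means a stronger inhibitor, a higher number a weaker inhibitor), compound 2 gives 28400 nM, the only number in the set. For compound 1 the value > 50000 nM is a limit of the assay, not a number. For compound 3 the value > 50000 nM is likewise a limit. Compound 4 `S=c1oc(-c2ccc3c(c2)OCCO3)nn1CN1CCN(c2cccc(Cl)c2)CC1` differs from compound 2 by 3-chlorophenyl in place of 2,4-dimethylphenyl on an amine nitrogen in a ring. Going by the values given here, the steps that bear on it are an at least 1.7-fold lower number from compound 1 to compound 2 (0.24 log units; that floor lies within the scatter) and an at least 1.7-fold higher number from compound 2 to compound 3 (0.24 log units; that floor lies within the scatter); both are set by the limit of > 50000 nM in this assay, at which 2 of the 3 values shown sit, rather than by numbers. The entering 3-chlorophenyl shares a chlorine with the 2,3-dichlorophenyl of compound 3, so a higher number than compound 2, possibly again a limit, is expected. Compound 4 is estimated at 42000 nM, range 20000 nM to 80000 nM, the expected step being a 1.5-fold higher number from compound 2 to compound 4 (0.17 log units; within the scatter).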

Compound 4, half-maximal inhibitory concentration: > 50000 nM
Compound 4 ended at the assay's limit; the forecaster's own chance of this, stated with the estimate: 45%; middle value at least 1.1-fold (0.07 log units) away from the limit.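

In this assay, 3-chlorophenyl in place of 2,4-dimethylphenyl on the ring amine nitrogen gives an at least 1.7-fold higher number from compound 2 to compound 4 (0.24 log units; that floor lies within the scatter). For the compounds shown here, compound 4 reads as a limit, not a number, so hydrogen in place of chloro relative to compound 3 does not yield a readable value, and compound 2 remains the only compound with a number. The steps among compound 1, compound 3 and compound 4 cannot be read, because all three sit at a limit: the limit of > 50000 nM in this assay, at which 3 of the 4 values shown sit.

Open, from the compounds shown here alone, is whether a benzyl group or an amine-bearing chain on this nitrogen would give a number. Also open, going by these compounds, is whether any group here moves the value beyond the scatter from compound 2.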